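The source may hold more compounds than are shown below. What is called first, only, known or untested is meant among the compounds shown, and "the series" means these compounds.

Measured compounds:
- compound 1 `COC(C(=O)OC(C)Cn1cnc2c1c(=O)n(C)c(=O)n2C)c1ccc(C(C)(C)C)cc1`: 28.6%
- compound 2 `CC(Cn1cnc2c1c(=O)n(C)c(=O)n2C)OCc1cn(CCCn2nc3c(Br)c(Br)c(Br)c(Br)c3n2)nn1`: 0%
- compound 3 `CC(Cn1cnc2c1c(=O)n(C)c(=O)n2C)OCc1cn(CCCn2cnc3c(Br)c(Br)c(Br)c(Br)c32)nn1`: 0%

The three compounds were tested in a functional assay on CCRF-CEM cells (Homo sapiens) for antiproliferative activity, read by MTT assay, with a stated time of 72 h, tested at 100 uM; a higher number here means a weaker effect of the compound at the concentration tested, a lower number a stronger effect. In this assay compound 1 gives 28.6%, the highest of the three numbers. Compound 2 gives 0% and compound 3 gives 0%, each of them lower than compound 1 by an amount beyond the scatter; compounds 2 and 3 are within the scatter of each other, so nothing separates them.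

Compound 4 `COC(C(=O)OC(C)Cn1cnc2c1c(=O)n(C)c(=O)n2C)c1cccc2ccccc12` differs from compound 1 in a single place: naphthalen-1-yl in place of 4-(tert-butyl)phenyl on a saturated chain carbon bound to a carbonyl carbon and an oxygen on a saturated carbon. The group that leaves and the group that enters are of the same size and carry neither donors nor acceptors. Among the compounds measured there is no pair that shows this change, so there is nothing to anchor its effect. The expectation is a small shift, if any, with no clear direction: the step of a number 1.4 percentage points higher from compound 1 to compound 4 (within the scatter) is expected to stay within the scatter. Compound 4 is therefore estimated at 30%, with a likely range from 8% to 58%.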

Compound 4, a percentage reported as activity, at one concentration (the size of the read-out at that concentration, not a potency): 51.4%
For compound 4 the middle estimate is 21.4 percentage points below the measured one, within the range that was stated.
By their numbers in this assay, from the lowest: compounds 2 and 3 (each within the scatter of the next); then compound 1; then compound 4.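

Placing naphthalen-1-yl instead of 4-(tert-butyl)phenyl on this saturated chain carbon gives a number 22.8 percentage points higher from compound 1 to compound 4 (beyond the scatter) in this assay, so the naphthalen-1-yl compound has the weaker effect at the concentration tested. Both groups hold 10 heavy atoms and carry no hydrogen-bond donors or acceptors, yet they are not interchangeable here, so matching these counts does not preserve the effect at this position; one visible difference is one six-membered aromatic ring against 2. No independent measurement is available to explain the shift.

A single step cannot separate the role of the second ring from that of the tert-butyl group, and a plain phenyl group at this place would be the simplest further comparison. From the compounds shown here alone, it also remains open how an amine in place of the oxygen on this chain carbon would fare with either aromatic group.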